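A few compounds are considered here, and "the series" means these few. Any claim that something is new, unique, unknown or untested is made for them only; others in the source may bear on it.

Measured so far: compound 1 `CCCOC(=O)C1=C(C)NC(=O)NC1c1ccoc1` gives 50% in an assay on membranes from CHO cells for displacement of a labelled ligand from adenosine receptor A1 (Homo sapiens), read by scintillation counting, with a stated time of 60 min, tested at 1 uM; on this read-out lower numbers stand for less inhibition and higher numbers for more inhibition at the one concentration tested (going by the name of the read-out); compound 2 `CCCC(=O)C1=C(C)NC(=O)NC1c1ccco1` gives 1%; compound 3 `CC1=C(C(=O)CC(C)C)C(c2ccco2)NC(=O)N1` gives 16%.

Compound 2 stands lowest of the three numbers, with compound 3 nearest and compound 1 furthest. The unmeasured compound 4 `CCCC(=O)C1=C(C)NC(=O)NC1c1ccoc1` differs from compound 2 in one place: furan-3-yl in place of furan-2-yl on a saturated ring carbon. Within the data shown here, the single measured step, a number 15 percentage points higher from compound 2 to compound 3 (beyond the scatter), concerns the propylcarbonyl chain and not the furan ring, so it does not bear on this change. Among the measured compounds shown here, compound 1 carries furan-3-yl and gives a far higher number than compound 2, but it differs from compound 2 in more than one place, so no step can be drawn. A modest rise is expected for compound 4, a number 14 percentage points higher from compound 2 to compound 4 (beyond the scatter), with the estimate for compound 4 at 15% (range 0% to 40%).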

Compound 4, a percentage reported as inhibition, at one concentration (the size of the read-out at that concentration, not a potency): 1%
For compound 4 the middle estimate is 14 percentage points above the measured one; low and high end bracket the measured number.
By their numbers in this assay, from the lowest: compounds 2 and 4 (each within the scatter of the next); then compound 3; then compound 1.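

In this assay furan-3-yl in place of furan-2-yl on the saturated ring carbon gives no change at the digits printed from compound 2 to compound 4 (within the scatter) with the propylcarbonyl group held in place, so this read-out does not separate the two furans in that setting. Propyl in place of propoxy on the carbonyl carbon gives a number 49 percentage points lower from compound 1 to compound 4 (beyond the scatter) with furan-3-yl held in place, which isolates the large gap to that carbonyl substituent. No measured evidence explains either result. From the compounds shown here alone, it remains open whether furan-2-yl would match furan-3-yl alongside propoxy. Also open, going by these compounds, is how an amine on the carbonyl carbon or a longer chain on its oxygen would read.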